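The compounds below may be only part of what the source reports. "The series", "measured", "known", "first", "only" and "open" are said of these compounds alone.

Measured compounds in an ADME assay on THP-1 cells (Homo sapiens) for cytotoxicity; a higher number here means that more compound is tolerated, a lower number that less compound is tolerated:
compound 1 `c1ccc(-c2nc3ccccn3c2NCC2CCO2)nc1`
compound 2 `Fc1cccc(Nc2c(-c3ccccn3)nc3ccccn23)c1`
compound 3 `N#Cc1ccc(Nc2c(-c3ccccn3)nc3ccccn23)cc1`

In this assay compound 1 gives only a limit, > 50000 nM. Compound 2 also gives only a limit, > 50000 nM. Compound 3 likewise gives only a limit, > 50000 nM. All three values sit at the limit of > 50000 nM in this assay, at which 3 of the 3 values shown sit, so none of the steps among them can be read: a step that the two limits leave unreadable from compound 1 to compound 2, a step that the two limits leave unreadable from compound 1 to compound 3 and a step that the two limits leave unreadable from compound 2 to compound 3. What the three compounds show together is that three different groups on the nitrogen on an aromatic ring, a (oxetan-2-yl)methyl, a 3-fluorophenyl and a 4-cyanophenyl, all leave the compound tolerated up to the limit of this assay.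

Compound 4 `COc1ccccc1Nc1c(-c2ccccn2)nc2ccccn12` has not been measured. It differs from compound 3 by 2-methoxyphenyl in place of 4-cyanophenyl on a nitrogen on an aromatic ring. The measured steps that bear on this change are those that exchange one group on the same nitrogen, and all of them are unreadable because every value sits at the limit of > 50000 nM in this assay, at which 3 of the 3 values shown sit; they give no size, only the absence of any toxicity within the tested range. Compound 4 is therefore expected to stay at the limit as well, with an estimate of 60000 nM and a range from 20000 nM to 150000 nM. The estimated step that the limit leaves unreadable from compound 3 to compound 4 is expected to be none beyond the scatter.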

Compound 4, half-maximal cytotoxic concentration: > 50000 nM
Compound 4 gave a limit, no number; the forecaster's own chance of this, stated with the estimate: 80%; the middle value does not contradict the limit.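

In this assay compound 4 also gives only a limit, > 50000 nM. Its steps from compound 1, compound 2 and compound 3 therefore cannot be read, because all four compounds stand at the same limit: the limit of > 50000 nM in this assay, at which 4 of the 4 values shown sit. The compounds shown leave open at what concentration any of them would become cytotoxic, and whether the groups on the nitrogen differ at all in this respect.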